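Hydroxamic acid series: tert-butyl for bromo on the aryl ring

A few compounds are considered here, and "the series" means these few. Any claim that something is new, unique, unknown or untested is made for them only; others in the source may bear on it.

Measured compounds:
compound 1 `Cc1ccc(CCCCN2CC=C(CCC(=O)NO)C2=O)cc1` — 3530 nM
compound 2 `O=C(CCC1=CCN(Cc2ccc(Br)cc2)C1=O)NO` — "not determined" (no result reported)

Within the data shown here, compound 1 `Cc1ccc(CCCCN2CC=C(CCC(=O)NO)C2=O)cc1` is the only member with a number in a functional assay on NUGC-3 cells (Homo sapiens) for inhibition, read by sulforhodamine B assay (on this read-out higher numbers stand for weaker inhibition of growth and lower numbers for stronger inhibition of growth), where compound 1 gives 3530 nM. Compound 2 `O=C(CCC1=CCN(Cc2ccc(Br)cc2)C1=O)NO` carries the same core on a shorter link to the aryl ring, but in this assay compound 2 stands at "not determined" (no result reported), so no number anchors it.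

Compound 3 `CC(C)(C)c1ccc(CN2CC=C(CCC(=O)NO)C2=O)cc1` is the next member, differing from compound 2 by tert-butyl in place of bromo on an aromatic carbon. Among the measured compounds shown here, with no numbered step between measured compounds, the size of the change cannot be read from the series; the expectation is no shift beyond the scatter of this assay, in either direction, and the only reference point is compound 1 with 3530 nM.

Compound 3 is therefore estimated at 3000 nM in this assay, with a range from 700 nM to 13000 nM.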

Compound 3, concentration for 50% growth inhibition in the NUGC-3 assay: 720 nM
Estimate against measurement, compound 3: 4.2-fold (0.62 log units) above; measured number inside the range.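

Among these compounds, no step in the NUGC-3 assay can be read from the result for compound 3: compound 2 stands at "not determined" (no result reported) and so offers no number to compare with compound 3 at 720 nM in this assay, and compound 1 differs from compound 3 in more than one place. The compounds shown leave open what tert-butyl in place of bromo does to the NUGC-3 assay read-out. In a physicochemical assay for lipophilicity (on this read-out lower numbers stand for lower lipophilicity and higher numbers for higher lipophilicity), compound 2 gives 1.26 and compound 3 gives 2.1 as measured, a number 0.84 log units higher from compound 2 to compound 3 (beyond the scatter) on this read-out.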